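Swapping 3,4-dimethoxyphenyl for thiophen-2-yl on the shared core

The source may report more compounds than this note shows. Statements on the series, on what has been measured and on what is new or still open speak of the compounds shown alone.

In a physicochemical assay for lipophilicity, measured as octanol-water partition (a higher number here means a more lipophilic compound, a lower number a more polar compound), compound 1 (`O=C(NNc1ccnc2cc(Cl)ccc12)c1ccccc1/N=C/c1ccccc1Cl`) gives 5.5 and compound 2 (`O=C(NNc1ccnc2cc(Cl)ccc12)c1ccccc1/N=C/c1ccc(Br)cc1`) gives 5.76 on this scale. Compound 3 (`COc1ccc(/C=N/c2ccccc2C(=O)NNc2ccnc3cc(Cl)ccc23)cc1OC`) stands lowest of the three at 4.97 and is the starting point here. Compound 4 (`O=C(NNc1ccnc2cc(Cl)ccc12)c1ccccc1/N=C/c1cccs1`) carries thiophen-2-yl in place of 3,4-dimethoxyphenyl on a carbon with a double bond to nitrogen. Three measured steps change this same place. The modest a number 0.53 log units lower from compound 1 to compound 3 (beyond the scatter) and a number 0.79 log units lower from compound 2 to compound 3 (beyond the scatter) both end at compound 3, while a number 0.26 log units higher from compound 1 to compound 2 (within the scatter) stays within the scatter. None of them involves thiophen-2-yl, so they offer only loose guidance, and no step beyond the scatter is expected in this assay. The estimated change is a number 0.12 log units lower from compound 3 to compound 4 (within the scatter) and so stays within the scatter. For compound 4 the estimated value is 4.85 with an expected range from 4.45 to 5.25 overall.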

Compound 4, partition coefficient: 4.78
For compound 4 the middle estimate is 0.07 log units above the measured one; the range from low to high includes it.
By their numbers in this assay, from the lowest: compounds 4 and 3 (each within the scatter of the next); then compounds 1 and 2 (each within the scatter of the next).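

In this assay, thiophen-2-yl, a five-membered aromatic ring, and 3,4-dimethoxyphenyl, a six-membered one, do not separate at this position on a carbon with a double bond to nitrogen (a number 0.19 log units lower from compound 3 to compound 4 (within the scatter)). Replacing 4-bromophenyl (a number 0.98 log units lower from compound 2 to compound 4 (beyond the scatter)) or 2-chlorophenyl (a number 0.72 log units lower from compound 1 to compound 4 (beyond the scatter)) with thiophen-2-yl, by contrast, gives steps beyond the scatter, so compound 4 joins compound 3 in the lower pair. Nothing available explains these differences. The compounds shown leave open how an aryl group carrying an amine or a carboxylic acid would read at this position.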